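Chain extension in a nucleotide series: notes toward compound 3

The source may report more compounds than this note shows. Statements on the series, on what has been measured and on what is new or still open speak of the compounds shown alone.

Measured so far:
compound 1 `O=C(CI)NCCCNc1ncnc2c1ncn2[C@@H]1O[C@H](COP(=O)(O)OP(=O)(O)OP(=O)(O)O)[C@@H](O)[C@H]1O` – 0%
compound 2 `O=C(CI)NCCCCCC(=O)NCCCNc1ncnc2c1ncn2[C@@H]1O[C@H](COP(=O)(O)OP(=O)(O)OP(=O)(O)O)[C@@H](O)[C@H]1O` – 0%

In an assay on isolated protein for inhibition of hexokinase-3 (Rattus norvegicus), with a stated time of 6 h, tested at 10 mM (on this read-out lower numbers stand for less inhibition and higher numbers for more inhibition at the one concentration tested (going by the name of the read-out)), compound 1 gives 0%. Compound 2 gives 0% in this assay. The one measured step, no change at the digits printed from compound 1 to compound 2 (within the scatter), lengthens the chain on the saturated carbon bound to the carbonyl carbon and produces nothing beyond the scatter; compound 1 therefore stands level with compound 2 at the digits shown, with no measured compound differing from it.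

Compound 3 `O=C(CI)NCCCCCCCNc1ncnc2c1ncn2[C@@H]1O[C@H](COP(=O)(O)OP(=O)(O)OP(=O)(O)O)[C@@H](O)[C@H]1O` differs from compound 1 by 4-(((iodomethyl)carbonyl)amino)butyl in place of ((iodomethyl)carbonyl)amino on a saturated chain carbon, three bonds along the chain from a nitrogen on an aromatic ring. Among the measured compounds shown here, the only step that bears on this change is no change at the digits printed from compound 1 to compound 2 (within the scatter), also a chain extension within the same series, and it was flat. The step of no change at the digits printed from compound 1 to compound 3 (within the scatter) is accordingly expected to show no change beyond the scatter. For compound 3 the estimate in this assay is 0%, with a range from 0% to 10%.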

Compound 3, a percentage reported as inhibition, at one concentration (the size of the read-out at that concentration, not a potency): 20%
For compound 3 the middle estimate is 20 percentage points below the measured one; the whole stated range lies below it.
By their numbers in this assay, from the lowest: compounds 1 and 2 (each within the scatter of the next); then compound 3.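

In this assay, among the compounds shown here, a number 20 percentage points higher from compound 1 to compound 3 (beyond the scatter) is the only step beyond the scatter, so the position on a saturated chain carbon, three bonds along the chain from a nitrogen on an aromatic ring, responds to 4-(((iodomethyl)carbonyl)amino)butyl in place of ((iodomethyl)carbonyl)amino. Added chain length therefore has no single outcome across the series, since the extension at the other place gives no change at the digits printed from compound 1 to compound 2 (within the scatter). The size of the step remains modest, and nothing available accounts for it.

As far as these compounds go, whether a longer chain than 7-(((iodomethyl)carbonyl)amino)heptyl would carry the number further remains open. Also open, from the compounds shown here alone, is whether the iodomethyl carbonyl group is needed at the chain end, a question that a plain heptyl chain or a terminal amine would address.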